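The source may report more compounds than this note shows. Statements on the series, on what has been measured and on what is new or still open speak of the compounds shown alone.

Measured compounds:
Compound 2 `CO[C@@H]1[C@H](N(C)c2ncc(-c3c[nH]c4ccc(F)cc34)s2)C[C@H]2O[C@]1(C)n1c3ccccc3c3c4c(c5c6cc(Br)ccc6n2c5c31)C(=O)NC4` — > 10000 nM in an ADME assay on PBMC cells (Homo sapiens) for cytotoxicity, read by CellTiter-Glo, with a stated time of 72 h; on this read-out lower numbers stand for stronger inhibition and higher numbers for weaker inhibition.
Compound 1 `CO[C@@H]1[C@H](N(C)c2ncc(-c3c[nH]c4ccc(Cl)cc34)s2)C[C@H]2O[C@]1(C)n1c3ccccc3c3c4c(c5c6cc(Cl)ccc6n2c5c31)C(=O)NC4` — > 10000 nM in this assay.

Both of these readings are limits of the assay, not measured numbers. For compound 2 the reading > 10000 nM means that no half-maximal inhibition of cell viability was reached at the highest concentration tested. Compound 1 sits at the same limit, as summarised by the limit of > 10000 nM in this assay, at which 2 of the 2 values shown sit, so on the numbers shown compound 2 stands on equal footing with the only other measured compound, and nothing places it higher or lower.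

Compound 3 `CO[C@@H]1[C@H](N(C)c2ncc(-c3c[nH]c4ccc(Cl)cc34)s2)C[C@H]2O[C@]1(C)n1c3ccccc3c3c4c(c5c6cc(Br)ccc6n2c5c31)C(=O)NC4` has not yet been measured in this assay. It differs from compound 2 in one place: chloro in place of fluoro on an aromatic carbon. The other halogen on the shared core stays as in compound 2, while the halogen on the indole matches that of compound 1. Because both measured compounds rest at the limit described by the limit of > 10000 nM in this assay, at which 2 of the 2 values shown sit, no step beyond the usual scatter is expected in this assay, in either direction.

For compound 3 the expected value in this assay is 15000 nM, with a range from 7000 nM to 50000 nM. The step this estimate implies, a step that the limit leaves unreadable from compound 2 to compound 3, is expected to be within the scatter, and most likely the assay will again report only a limit.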

Compound 3, half-maximal inhibitory concentration: > 10000 nM
Compound 3 gave a limit, no number; the forecaster's own chance of this, stated with the estimate: 85%; the middle value does not contradict the limit.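

In this assay compound 3 gives > 10000 nM, which is a limit and not a number. The steps from compound 2 and from compound 1 to compound 3 cannot be read, because all three compounds rest at the same limit: the limit of > 10000 nM in this assay, at which 3 of the 3 values shown sit.

The compounds shown leave open whether swapping these halogens changes cytotoxicity at all, and at what concentration any of the three would reach half-maximal inhibition.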